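Cytotoxicity notes: formyl to benzyl ester swap

The compounds below may be only part of what the source reports. "The series", "measured", "known", "first", "only" and "open" are said of these compounds alone.

In an ADME assay on HEK293 cells (Homo sapiens) for cytotoxicity, with a stated time of 72 h (a higher number here means that more compound is needed for the effect, a lower number that less compound is needed), compound 1 (`C=C[C@@](C)(/C=C/c1ccc(O)cc1)CC/C=C(C)/C=C/C(=O)OCc1ccccc1`) gives > 36600 nM, which is a limit of the assay. Compound 2 (`C=C[C@@](C)(/C=C/c1ccc(O)c(/C=C/C(=O)O)c1)CCC=C(C)C`) gives > 36600 nM, again a limit. Among the compounds with values here, compound 3 (`COc1ccc(/C=C/[C@@](C)(/C=C/c2ccc(O)c(C=O)c2)CCC=C(C)C)cc1`) gives 2270 nM, the only true number in the set so far.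

Compound 4 (`COc1ccc(/C=C/[C@@](C)(/C=C/c2ccc(O)c(/C=C/C(=O)OCc3ccccc3)c2)CCC=C(C)C)cc1`) is still unmeasured. Its change from compound 3 is 2-(benzyloxycarbonyl)ethenyl in place of formyl on an aromatic carbon, ortho to a hydroxy group.

Within the data shown here, no measured pair isolates this change, so the expectation rests on thin ground. Compound 1, which also carries a benzyloxycarbonyl-type ester, reads > 36600 nM, a limit. Compound 2, which has no formyl, reads > 36600 nM, also a limit. The expected move in this assay is therefore toward more compound being needed, beyond the scatter, and the assay may return only a limit. The expected step is a 4.8-fold higher number from compound 3 to compound 4 (0.69 log units; beyond the scatter). For compound 4 the estimate is 11000 nM, with an expected range of 3500 nM to 36600 nM.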

Compound 4, half-maximal effective concentration: > 36600 nM
Compound 4 was reported as a limit; the forecaster's own chance of this, stated with the estimate: 35%; at least 3.3-fold (0.52 log units) between middle value and limit.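

In this assay, within the data shown here, 2-(benzyloxycarbonyl)ethenyl in place of formyl on an aromatic carbon, ortho to a hydroxy group, gives an at least 16-fold higher number from compound 3 to compound 4 (1.20 log units; beyond the scatter), the first comparison that isolates a change at this position. Among these compounds, compound 1 and compound 2 differ from compound 3 in more than one place, so only this pair ties the loss of the measurable cytotoxicity reading to this carbon. The step is a lower bound and not a measured size, and compound 4 is reported only as a limit: the limit of > 36600 nM in this assay, at which 3 of the 4 values shown sit.

The pair does not separate the loss of formyl from the entry of the larger ester group. A hydroxymethyl, a carboxylic acid or an amine on this carbon of the core of compound 3 would bear on that question.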